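Trimethoxyphenyl in Place of Methoxyphenyl on a Shared Core

The source may hold more compounds than are shown below. What is called first, only, known or untested is meant among the compounds shown, and "the series" means these compounds.

Of the compounds shown here, three that share one core have been tested in a functional assay on Huh-7 cells (Homo sapiens) for antiproliferative activity, read by sulforhodamine B assay, with a stated time of 72 h; on this read-out lower numbers stand for stronger inhibition and higher numbers for weaker inhibition. Compound 1 `N#Cc1ccccc1COc1ccc(-c2cc(CN3CCN(Cc4ccc(C(F)(F)F)cc4)CC3)no2)cc1` gives 5000 nM in this assay. Compound 2 `Fc1cccc(COc2ccc(-c3cc(CN4CCN(Cc5ccc(C(F)(F)F)cc5)CC4)no3)cc2)c1` gives 1300 nM in this assay. Compound 3 `COc1ccccc1COc1ccc(-c2cc(CN3CCN(Cc4ccc(C(F)(F)F)cc4)CC3)no2)cc1` gives 900 nM in this assay, the lowest number of the three, though its gap to compound 2 lies within the scatter. The steps of a 3.8-fold lower number from compound 1 to compound 2 (0.59 log units; beyond the scatter) and a 5.6-fold lower number from compound 1 to compound 3 (0.74 log units; beyond the scatter) are beyond the scatter, while the step of a 1.4-fold lower number from compound 2 to compound 3 (0.16 log units; within the scatter) is not.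

Compound 4 `COc1cc(COc2ccc(-c3cc(CN4CCN(Cc5ccc(C(F)(F)F)cc5)CC4)no3)cc2)cc(OC)c1OC` is not yet measured. It differs from compound 3 in one place: 3,4,5-trimethoxyphenyl in place of 2-methoxyphenyl on a saturated chain carbon bound to an oxygen on an aromatic ring. Among the compounds with values here, no measured step exchanges one methoxy-bearing ring for another, so the guidance is indirect: the step of a 5.6-fold lower number from compound 1 to compound 3 (0.74 log units; beyond the scatter) shows a methoxy going with a lower number than a nitrile, and the step of a 1.4-fold lower number from compound 2 to compound 3 (0.16 log units; within the scatter) shows that swapping rings at this position can change little. Compound 4 is therefore expected to land near compound 3. Compound 4 is estimated at 1000 nM in this assay, with a range from 300 nM to 3500 nM. The expected step of a 1.1-fold higher number from compound 3 to compound 4 (0.05 log units; within the scatter) is within the scatter.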

Compound 4, half-maximal inhibitory concentration: 500 nM
For compound 4 the middle estimate is 2.0-fold (0.30 log units) above the measured one, and the stated range covers the measured number.
By their numbers in this assay, from the lowest: compounds 4, 3 and 2 (each within the scatter of the next, the first and the last beyond it); then compound 1.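

Placing 3,4,5-trimethoxyphenyl, with 12 heavy atoms, in place of 2-methoxyphenyl, with 8, on a saturated chain carbon bound to an oxygen on an aromatic ring gives a 1.8-fold lower number from compound 3 to compound 4 (0.26 log units; within the scatter) in this assay, so this larger group keeps the number in the same range as compound 3. Compound 4 does separate from a ring that compound 3 could not, with a 2.6-fold lower number from compound 2 to compound 4 (0.41 log units; beyond the scatter), and the set now spans a 10-fold lower number from compound 1 to compound 4 (1.00 log units; beyond the scatter), the widest step among these compounds. No evidence is available on what lies behind these steps.

Which methoxy groups of the 3,4,5-trimethoxyphenyl matter stays open, as no 3,4-dimethoxyphenyl stands among these compounds. As far as these compounds go, how a ring bearing an amine or a carboxylic acid would read in this assay also stays open.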